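Hydroxy for Chloro on Two Related Cores

A few compounds are considered here, and "the series" means these few. Any claim that something is new, unique, unknown or untested is made for them only; others in the source may bear on it.

Three compounds have been measured in an assay with Cystic fibrosis transmembrane conductance regulator (Rattus norvegicus) as the target; on this read-out lower numbers stand for tighter binding and higher numbers for weaker binding:

compound 1, `ClCc1cc(-c2ccccc2OCc2ccc(Br)cc2)no1`: 220000 nM
compound 2, `OCc1cc(-c2ccccc2OCc2ccc(Br)cc2)no1`: 147000 nM
compound 3, `COc1ccc(COc2ccc(Br)cc2-c2cc(CCl)on2)cc1`: > 300000 nM, a limit rather than a number

Compound 2 differs from compound 1 by hydroxy in place of chloro on a saturated chain carbon bound to an aromatic carbon, and this gave a 1.5-fold lower number from compound 1 to compound 2 (0.18 log units; within the scatter). For compound 3 this assay reports only a limit, (the limit of > 300000 nM in this assay, at which 1 of the 3 values shown sits). The difference between the core of compound 1 and the core of compound 3 is not broken down here. Compound 4, `COc1ccc(COc2ccc(Br)cc2-c2cc(CO)on2)cc1`, has not yet been measured; it differs from compound 3 by hydroxy in place of chloro on a saturated chain carbon bound to an aromatic carbon, the same change as that from compound 1 to compound 2, at a place described in the same words. Since compound 1 and compound 2 showed a 1.5-fold lower number from compound 1 to compound 2 (0.18 log units; within the scatter), the new step is expected to be similarly small, an at least 1.2-fold lower number from compound 3 to compound 4 (0.07 log units; that floor lies within the scatter). Compound 4 is therefore estimated at 250000 nM, between 120000 nM and 600000 nM, with a fair chance that this assay again reports only a limit.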

Compound 4, dissociation constant: 104000 nM
Compound 4: middle estimate off by 2.4-fold (0.38 log units), on the high side, outside the stated range (below it).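

In this assay, hydroxy in place of chloro on the second core gave an at least 2.8-fold lower number from compound 3 to compound 4 (0.46 log units; beyond the scatter). Whether the change carries over from one core to the other with the same size stays undecided: the same change on two cores in this assay, a 1.5-fold lower number (0.18 log units; within the scatter) from compound 1 to compound 2 and an at least 2.8-fold lower number (0.46 log units; beyond the scatter) from compound 3 to compound 4; the limit leaves it open whether they differ The reading for compound 3 is a limit and not a number, so the new step is only a floor: the limit of > 300000 nM in this assay, at which 1 of the 4 values shown sits.

The compounds shown leave open whether an amine, a carboxylic acid or a longer chain in place of hydroxymethyl would give a different result in this assay. They also leave open how the change from chloromethyl to hydroxymethyl would read on any further core.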